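The compounds below may be only part of what the source reports. "The series", "measured", "known", "first", "only" and "open" are said of these compounds alone.

Measured in an ADME assay on microsomes from liver (Homo sapiens) for metabolic stability, read by LC-MS, using NADPH, with a stated time of 45 min, tested at 3 uM; a higher number here means that the compound lasts longer, a lower number that the compound disappears faster:
- compound 1 `C1CCC(C(CC2CCCCN2)C2CCC2)CC1`: > 3.33 h (a limit)
- compound 2 `C1CCC(CC(C2CCCC2)C2CC2)NC1`: 0.45 h
- compound 3 `CC1(C)CCC(C(CC2CCCCN2)C2CCCCC2)CC1`: 1.28 h

Compound 1 is known only as a limit, > 3.33 h, and not as an exact number. Compound 4 `FC1CCC(C(CC2CCCCN2)C2CCCCC2)CC1` differs from it as follows: 4-fluorocyclohexyl in place of cyclobutyl on a saturated chain carbon bound to a saturated chain carbon and a saturated ring carbon. The 4-fluorocyclohexyl takes the place of cyclobutyl on a saturated chain carbon bound to a saturated chain carbon and a saturated ring carbon. Among the measured compounds shown here, no measured step shows what such a swap does. The expectation therefore rests on the two exact numbers available, with compound 2 at 0.45 h and compound 3 at 1.28 h. In this assay, the estimated step of an at least 2.2-fold lower number from compound 1 to compound 4 (0.34 log units; beyond the scatter) is a fall larger than the usual scatter. Compound 4 is expected at 1.5 h, within an estimated range of 0.7 h to 3.3 h.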

Compound 4, half-life: 1.08 h
Compound 4: middle estimate off by 1.4-fold (0.14 log units), on the high side; low and high end bracket the measured number.
By their numbers in this assay, from the lowest: compound 2; then compounds 4 and 3 (each within the scatter of the next). At a limit, above all of these: compound 1.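

Among the compounds shown here, compounds 1 to 3 gave no measured step at this position, on a saturated chain carbon bound to a saturated chain carbon and a saturated ring carbon. In this assay, 4-fluorocyclohexyl in place of cyclobutyl gives an at least 3.0-fold lower number from compound 1 to compound 4 (0.48 log units; beyond the scatter), so in this one pair the group at this place changes how long the compound lasts. Compound 1 is known only as a limit, so this step is a minimum: the limit of > 3.33 h in this assay, at which 1 of the 4 values shown sits.

This single pair cannot separate the larger ring from the fluorine. On these data alone, what an amine or a carboxylic acid on that ring would do also remains open.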